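The source may hold more compounds than are shown below. What is called first, only, known or untested is meant among the compounds shown, and "the series" means these compounds.

Compound 1 `Nc1cc(C2CCC2)nc2ccc(NC(=O)/C=C/c3ccc(C(F)(F)F)cc3)cc12` has the lowest number of the two measured here: in an assay on isolated protein for displacement of a labelled ligand from melanin-concentrating hormone receptor 1 (Homo sapiens) (a higher number here means a weaker inhibitor, a lower number a stronger inhibitor), compound 1 gives 2 nM. Compound 2 `CCCc1cc(N)c2cc(NC(=O)/C=C/c3cccc(Cl)c3)ccc2n1`, which differs from it in several places at once, gives 1100 nM in this assay, a gap well beyond the usual scatter. Compound 3 `CC(C)c1cc(N)c2cc(NC(=O)/C=C/c3ccc(C(F)(F)F)cc3)ccc2n1` keeps everything of compound 1 except one change: isopropyl in place of cyclobutyl on an aromatic carbon. Among the compounds with values here, with no measured pair showing this exact swap, only a small step is expected, if any beyond the scatter, and compound 3 is estimated at 4 nM (range 1 nM to 20 nM), which would mean a step of a 2.0-fold higher number from compound 1 to compound 3 (0.30 log units; within the scatter) from compound 1.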

Compound 3, half-maximal inhibitory concentration: 2.1 nM
Compound 3: the middle estimate sits 1.9-fold (0.28 log units) above what was measured, and the stated range covers the measured number.
By their numbers in this assay, from the lowest: compounds 1 and 3 (each within the scatter of the next); then compound 2.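

In this assay, isopropyl in place of cyclobutyl on this aromatic carbon, next to the ring nitrogen, gives a 1.1-fold higher number from compound 1 to compound 3 (0.02 log units; within the scatter) and so leaves the two compounds indistinguishable. With the rest of compound 1 kept, a closed four-membered ring at this position is therefore not required, and an open, branched group of one heavy atom fewer serves equally well. No measurement here explains this result. As far as these compounds go, what remains open is how far this tolerance extends: whether a single methyl, an amine or a carboxylic acid at this position would hold up equally well.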